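Cytotoxicity of a bisulfite adduct carrying an indole cap

The source may hold more compounds than are shown below. What is called first, only, known or untested is meant among the compounds shown, and "the series" means these compounds.

Compound 1 `COc1cccc2[nH]c(C(=O)N[C@@H](CC3CC3)C(=O)N[C@H](C=O)C[C@@H]3CCNC3=O)cc12`: in an ADME assay on Vero C1008 cells (Chlorocebus sabaeus) for cytotoxicity, read by luminescence and CellTiter-Glo, with a stated time of 24 h (on this read-out higher numbers stand for lower toxicity in this test and lower numbers for higher toxicity in this test), compound 1 gives > 200000 nM, a limit of the assay.
Compound 2 `O=C(N[C@@H](CC1CC1)C(=O)N[C@@H](C[C@@H]1CCNC1=O)C(O)S(=O)(=O)O)OCc1cccc(F)c1`: in this assay compound 2 gives > 200000 nM, a limit of the assay.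
Compound 3 `O=C(N[C@@H](CC1CC1)C(=O)N[C@@H](C[C@@H]1CCNC1=O)C(O)S(=O)(=O)O)OCCc1cccc(Cl)c1`: in this assay compound 3 gives > 200000 nM, a limit of the assay.

Compound 3 stands at the limit, together with the other two measured compounds (the limit of > 200000 nM in this assay, at which 3 of the 3 values shown sit). For the measured compounds named here, the one step measured within this set, a step that the two limits leave unreadable from compound 2 to compound 3, runs between two limits and its size cannot be read. Compound 4 `COc1cccc2[nH]c(C(=O)N[C@@H](CC3CC3)C(=O)N[C@@H](C[C@@H]3CCNC3=O)C(O)S(=O)(=O)O)cc12` differs from compound 3 by 4-methoxy-1H-indol-2-yl in place of 2-(3-chlorophenyl)ethoxy on a carbonyl carbon. The entering group is the same cap that compound 1 carries, and compound 1 also sits at the limit (the limit of > 200000 nM in this assay, at which 3 of the 3 values shown sit), so no measured step gives a reason to expect a number below the limit. The step of a number no higher from compound 3 to compound 4 (the limit leaves the size open) from compound 3 to compound 4 is therefore expected to stay within the scatter. Compound 4 is estimated to give 200000 nM, with a range from 100000 nM to 400000 nM, and most likely to be reported as a limit again.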

Compound 4, half-maximal cytotoxic concentration: > 200000 nM
Compound 4: only a limit was reported; the forecaster's own chance of this, stated with the estimate: 85%; the middle value sits exactly at the limit.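

Compound 4 also sits at a limit of the assay, so the steps to it from compound 1, compound 2 and compound 3 cannot be read: the limit of > 200000 nM in this assay, at which 4 of the 4 values shown sit. The compounds shown leave open at what concentration any of them would turn toxic in this assay and whether the cap changes that concentration at all.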